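The source may hold more compounds than are shown below. What is called first, only, known or untested is meant among the compounds shown, and "the series" means these compounds.

Compound 1 `CCCCCCCO/N=C/c1cc(OC)c2c(c1OC)C(=O)C=CC2=O`: in a functional assay on A549 cells (Homo sapiens) for antiproliferative activity (on this read-out higher numbers stand for an effect only at larger amounts of compound and lower numbers for an effect already at smaller amounts), compound 1 gives > 10 ug/mL, a limit of the assay rather than a number.
Compound 2 `COc1cc(/C=N/OCc2ccccc2)c(OC)c2c1C(=O)C=CC2=O`: compound 2 gives > 10 ug/mL, again a limit.
Compound 3 `CCCO/N=C/c1cc(OC)c2c(c1OC)C(=O)C=CC2=O`: compound 3 gives > 10 ug/mL, also a limit.

Going by the values given here, compound 3 therefore stands at the limit of > 10 ug/mL in this assay, at which 3 of the 3 values shown sit, together with every other measured member of the series; no measured compound sits apart from it. Compound 4 `CCCCCCCCCO/N=C/c1cc(OC)c2c(c1OC)C(=O)C=CC2=O` differs from compound 3 by hexyl in place of hydrogen on a saturated chain carbon, three bonds along the chain from an oxygen on an unsaturated carbon. The step that bears most directly on this change is a step that the two limits leave unreadable from compound 1 to compound 3, which runs along the same chain; a step that the two limits leave unreadable from compound 1 to compound 2 and a step that the two limits leave unreadable from compound 2 to compound 3 are equally unreadable. Among the compounds with values here, no measured step gives a readable size or direction, so no step beyond the scatter can be expected for a step that the limit leaves unreadable from compound 3 to compound 4. Compound 4 is estimated at 15 ug/mL, with a range from 5 ug/mL to 50 ug/mL, most likely reported again as a limit.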

Compound 4, concentration for half-maximal effect: > 10 ug/mL
Compound 4 was reported as a limit; the forecaster's own chance of this, stated with the estimate: 75%; the middle value is on the limit's open side.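

In this assay compound 4 gives > 10 ug/mL, a limit. No step linking compound 4 to compound 1, compound 2 or compound 3 can be read: the limit of > 10 ug/mL in this assay, at which 4 of the 4 values shown sit.

The compounds shown leave open whether any of these chains on the shared core has a readable effect in this assay.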